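The compounds below may be only part of what the source reports. "The series", "measured", "known", "first", "only" and "open" are said of these compounds alone.

Read-out in an assay for binding affinity to dual specificity mitogen-activated protein kinase kinase 4 (Homo sapiens), read by KINOMEscan, tested at 100 nM (on this read-out lower numbers stand for a stronger effect and higher numbers for a weaker effect at the one concentration tested), for the measured members of the series:

compound 1 `CCCS(=O)(=O)Nc1ccc(F)c(C(=O)c2n[nH]c3ncc(-c4ccc(F)cc4)cc23)c1F`: 2.1%
compound 2 `CCCS(=O)(=O)Nc1ccc(F)c(C(=O)c2n[nH]c3ncc(-c4cccc(OC)c4)cc23)c1F`: 6.3%
compound 3 `CCCS(=O)(=O)Nc1ccc(F)c(C(=O)c2n[nH]c3ncc(-c4ccc(O)cc4)cc23)c1F`: 0.75%

Compound 2 carries the highest of the three numbers, yet neither neighbour is separated from it beyond the scatter: the step of a number 4.2 percentage points higher from compound 1 to compound 2 (within the scatter) and the step of a number 5.6 percentage points lower from compound 2 to compound 3 (within the scatter) both stay within it, as does a number 1.4 percentage points lower from compound 1 to compound 3 (within the scatter). The three aryl variants on the shared core therefore read as one cluster of low numbers in this assay, with no order among them that can be trusted.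

Compound 4 `CCCS(=O)(=O)Nc1ccc(F)c(C(=O)c2n[nH]c3ncc(-c4cc(Cl)cc(Cl)c4)cc23)c1F` has not yet been measured. It differs from compound 2 by 3,5-dichlorophenyl in place of 3-methoxyphenyl on an aromatic carbon. Going by the values given here, the steps that bear on this change are the three aryl exchanges already made: 4-fluorophenyl to 3-methoxyphenyl, 3-methoxyphenyl to 4-hydroxyphenyl, and fluoro to hydroxy, each within the scatter. Nothing in the series points to an aryl substituent that moves the number in this assay beyond the scatter, so for compound 4 no step beyond the scatter is expected, and the expected step is a number 2.3 percentage points lower from compound 2 to compound 4 (within the scatter). The estimate for compound 4 in this assay is 4%, with a range from 0.5% to 15%.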

Compound 4, a percentage reported as activity, at one concentration (the size of the read-out at that concentration, not a potency): 73%
The estimate for compound 4 lay 69 percentage points below the measured number; the whole stated range lies below it.
By their numbers in this assay, from the lowest: compounds 3, 1 and 2 (each within the scatter of the next); then compound 4.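

In this assay, this position on the shared core does respond to the aryl group: 3,5-dichlorophenyl in place of 3-methoxyphenyl gives a number 66.7 percentage points higher from compound 2 to compound 4 (beyond the scatter), in place of 4-hydroxyphenyl a number 72.3 percentage points higher from compound 3 to compound 4 (beyond the scatter), and in place of 4-fluorophenyl a number 70.9 percentage points higher from compound 1 to compound 4 (beyond the scatter). The earlier exchanges stayed within the scatter, so their agreement holds only for compounds 1, 2 and 3, with compound 4 going against it, and 3-methoxyphenyl and 3,5-dichlorophenyl have the same heavy-atom count, so that count does not separate compound 2 from compound 4. Nothing available gives a cause for these steps.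

Open, on these data alone, is whether the steps follow from chlorine itself or from the substitution pattern of 3,5-dichlorophenyl: 3-chlorophenyl and 4-chlorophenyl would test the halogen alone, and 3,5-dimethoxyphenyl or 3,5-dimethylphenyl would test the pattern without chlorine. Also open, as far as these compounds go, is how this position responds to a phenyl ring bearing an amine or a carboxylic acid, groups absent from these four compounds.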